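Acyl variation on the piperidine nitrogen of the series

The source may hold more compounds than are shown below. What is called first, only, known or untested is meant among the compounds shown, and "the series" means these compounds.

Compound 3 `COc1cc(N)c(Cl)cc1C(=O)N[C@H]1CCN(CC2CCN(C(C)=O)CC2)C[C@H]1OC` gives 592 nM in an assay on COS-7 cells for displacement of a labelled ligand from 5-hydroxytryptamine receptor 4 (Homo sapiens), read by scintillation counting, with a stated time of 30 min (a higher number here means a weaker inhibitor, a lower number a stronger inhibitor), the second highest of the three numbers: compound 1 `COc1cc(N)c(Cl)cc1C(=O)N[C@H]1CCN(CCCn2cncn2)C[C@H]1OC` gives 1270 nM, compound 2 `COc1cc(N)c(Cl)cc1C(=O)N[C@H]1CCN(CC2CCN(C(=S)C(C)C)CC2)C[C@H]1OC` gives 155 nM. Compound 4 `COc1cc(N)c(Cl)cc1C(=O)N[C@H]1CCN(CC2CCN(C(=O)N(C)C)CC2)C[C@H]1OC` is not yet measured; it differs from compound 3 by dimethylamino in place of methyl on a carbonyl carbon.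

Among the measured compounds shown here, the only step at this position is a 3.8-fold higher number from compound 2 to compound 3 (0.58 log units; beyond the scatter), a modest change on the ring nitrogen. The steps of an 8.2-fold lower number from compound 1 to compound 2 (0.91 log units; beyond the scatter) and a 2.1-fold lower number from compound 1 to compound 3 (0.33 log units; beyond the scatter) concern a different part and bear less directly. For the measured compounds named here, no measured pair shows acetyl against dimethylcarbamoyl, so the direction is open; a step within the scatter, or a modest lower number, is expected.

For compound 4 the expected value in this assay is 400 nM, range 150 nM to 1100 nM, an expected step of a 1.5-fold lower number from compound 3 to compound 4 (0.17 log units; within the scatter).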

Compound 4, half-maximal inhibitory concentration: 52 nM
The estimate for compound 4 lay 7.7-fold (0.89 log units) above the measured number, and the stated range ends above it.
By their numbers in this assay, from the lowest: compound 4; then compound 2; then compound 3; then compound 1.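

In this assay, the group on the carbonyl carbon proves a strong lever: dimethylamino in place of methyl gives (an 11-fold lower number from compound 3 to compound 4 (1.06 log units; beyond the scatter)), larger than the earlier step on the ring nitrogen (a 3.8-fold higher number from compound 2 to compound 3 (0.58 log units; beyond the scatter)). The dimethylcarbamoyl group now carries the lowest number of the series, with (a 3.0-fold lower number from compound 2 to compound 4 (0.47 log units; beyond the scatter)) and (a 24-fold lower number from compound 1 to compound 4 (1.39 log units; beyond the scatter)) both beyond the scatter. No supporting measurement accounts for the size of these steps.

Open, on these data alone, is whether this gain is specific to dimethylamino or extends to diethylamino, or to a ring amine such as pyrrolidin-1-yl. Methoxy on the same carbonyl carbon would test whether the nitrogen itself is needed.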